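The compounds below may be only part of what the source reports. "The series", "measured", "known", "first", "only" and "open" are said of these compounds alone.

Measured compounds in a functional assay on SK-OV-3 cells (Homo sapiens) for antiproliferative activity, read by MTT assay, with a stated time of 24 h; a lower number here means a stronger inhibitor, a higher number a weaker inhibitor:
compound 1 `COc1ccc(C(=O)/C=C/c2ccc(F)cc2)c2c1C=CC(C)(C)O2` > 10000 nM
compound 2 `COc1ccc(C(=O)/C=C/c2ccsc2)c2c1C=CC(C)(C)O2` > 10000 nM
compound 3 `COc1ccc(C(=O)/C=C/c2ccc(Cl)c(Cl)c2)c2c1C=CC(C)(C)O2` 9940 nM

The value of compound 1 in this assay is a limit, not a number. The value of compound 2 in this assay is likewise a limit. Among the measured compounds shown here, compound 3 therefore holds the only number among the three, and it sits close to the limit of > 10000 nM in this assay, at which 2 of the 3 values shown sit.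

Compound 4 `COc1ccccc1/C=C/C(=O)c1ccc(OC)c2c1OC(C)(C)C=C2` differs from compound 3 by 2-methoxyphenyl in place of 3,4-dichlorophenyl on a double-bonded chain carbon bound to a double-bonded chain carbon. For the measured compounds named here, three measured steps touch this position, and none of them can be read in size: a number no higher from compound 1 to compound 3 (the limit leaves the size open), a number no higher from compound 2 to compound 3 (the limit leaves the size open) and a step that the two limits leave unreadable from compound 1 to compound 2. Each changes the aryl group on the double-bonded chain carbon, yet the limits leave open whether any of them moved the potency at all. The step to compound 4 is another change of that aryl group, so no direction beyond the scatter can be drawn from what is known.

Compound 4 is accordingly expected to land near where compound 3 stands, at an estimated 9000 nM (range 3000 nM to 30000 nM), which means an expected step of a 1.1-fold lower number from compound 3 to compound 4 (0.04 log units; within the scatter), with a fair chance that only a limit is reported.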

Compound 4, half-maximal inhibitory concentration: > 10000 nM
Compound 4: only a limit was reported; the forecaster's own chance of this, stated with the estimate: 55%; middle value at least 1.1-fold (0.04 log units) from the limit.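

In this assay, putting 2-methoxyphenyl at this place on the double-bonded chain carbon gives a number no lower from compound 3 to compound 4 (the limit leaves the size open). Among the compounds shown here, the first group tried here that carries a hydrogen-bond acceptor therefore brings no readable gain, and compound 3, with its 3,4-dichlorophenyl group, remains the only compound with a number. The series now gathers at one edge of the assay's range: the limit of > 10000 nM in this assay, at which 3 of the 4 values shown sit.

On these data alone, the steps among compound 1, compound 2 and compound 4 cannot be read, so whether these three differ from one another remains open. Also open, as far as these compounds go, is whether an amine or a carboxylic acid in place of these groups would give a number clearly lower than that of compound 3.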